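The compounds below may be only part of what the source reports. "The series", "measured", "known", "first", "only" and "open" are said of these compounds alone.

Compound 1 `CCCNc1nc(NCc2ccc(NC(=O)c3ccc(F)cc3)cc2)c2ccccc2n1` gives 1700 nM in a functional assay on HCT-116 cells (Homo sapiens) for inhibition, read by luminescence and resazurin assay, with a stated time of 3 days; a higher number here means a weaker inhibitor, a lower number a stronger inhibitor. Compound 2 `CCCNc1nc(NCc2ccc(C(=O)Nc3ccc(F)cc3)cc2)c2ccccc2n1` gives 1500 nM in this assay.

Compound 2 holds the lower of the two numbers, yet the gap a 1.1-fold lower number from compound 1 to compound 2 (0.05 log units; within the scatter) lies within the scatter, so the two cannot be told apart. Compound 3 `CC1CN(c2nc(NCc3ccc(C(=O)Nc4ccc(F)cc4)cc3)c3ccccc3n2)CCN1` differs from compound 2 by 3-methylpiperazin-1-yl in place of propylamino on an aromatic carbon. Among the compounds with values here, the only measured step, a 1.1-fold lower number from compound 1 to compound 2 (0.05 log units; within the scatter), concerns another part of the molecule and says nothing about this exchange; no measured step in this assay bears on it. Compound 3 is therefore expected to land near its parent, estimated at 1500 nM with a wide range from 350 nM to 6500 nM, an expected step of no change at the digits printed from compound 2 to compound 3 (within the scatter).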

Compound 3, half-maximal inhibitory concentration: 2800 nM
Compound 3: the middle estimate sits 1.9-fold (0.27 log units) below what was measured, within the range that was stated.
By their numbers in this assay, from the lowest: compounds 2, 1 and 3 (each within the scatter of the next).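

Placing 3-methylpiperazin-1-yl instead of propylamino on the aromatic carbon between two ring nitrogen atoms gives, in this assay, a 1.9-fold higher number from compound 2 to compound 3 (0.27 log units; within the scatter). This carbon of the core can therefore carry either an open chain or a six-membered non-aromatic ring with more heavy atoms, with no difference that the assay can separate from scatter. Nothing available here offers an explanation for this result. Still open, on these data alone, is whether a plain amine, or piperazine without its methyl, would move the number beyond the scatter.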